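Methoxy to chloro on the aryl ring, two cores

A few compounds are considered here, and "the series" means these few. Any claim that something is new, unique, unknown or untested is made for them only; others in the source may bear on it.

Measured so far:
compound 1 `COc1cccc(C2CCc3nc[nH]c3C2)c1` — 60%
compound 2 `COc1ccc(C2Cc3nccn3C2)cc1` — 27%
compound 3 `Clc1ccc(C2Cc3nccn3C2)cc1` — 45%

In a functional assay on CHO cells for agonist activity at Alpha-1A adrenergic receptor (Homo sapiens), read by FLIPR and calcium flux (a higher number here means a larger maximal response, a lower number a smaller maximal response), compound 1 gives the highest of the three numbers; compound 3 stands nearest, compound 2 furthest. Compound 2 and compound 3 share one core and differ in one place, (chloro in place of methoxy on an aromatic carbon); the step is a number 18 percentage points higher from compound 2 to compound 3 (beyond the scatter). The difference between the core of compound 1 and the core of compound 2 is not broken down here.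

Compound 4 `Clc1cccc(C2CCc3nc[nH]c3C2)c1` has not been measured in this assay. It differs from compound 1 by chloro in place of methoxy on an aromatic carbon. This is the same kind of change as from compound 2 to compound 3, but the two places are not the same: in compound 1 the group sits meta to a group of 9 heavy atoms, in compound 2 para to a group of 8 heavy atoms.

The expected step from compound 1 to compound 4 in this assay is a number 12 percentage points higher from compound 1 to compound 4 (beyond the scatter), an expectation resting on a single shown step, taken with caution because the step of a number 18 percentage points higher from compound 2 to compound 3 (beyond the scatter) was measured on a different core and at a different place, and because compound 1 gives 60%, a maximal response that leaves less room upward than compound 2 had. For compound 4 the expected value is 72%, with a range from 55% to 90%.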

Compound 4, largest response reached (Emax), in percent of the reference or control that the assay uses in the Alpha-1A adrenergic receptor assay: 71%
Compound 4: middle estimate off by 1 percentage points, on the high side, and the stated range covers the measured number.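

In the Alpha-1A adrenergic receptor assay, chloro in place of methoxy on an aromatic carbon gives a number 11 percentage points higher from compound 1 to compound 4 (beyond the scatter), so the change carries from one core to the other in direction, and the two steps do not differ in size beyond the scatter: the same change on two cores in the Alpha-1A adrenergic receptor assay, a number 18 percentage points higher (beyond the scatter) from compound 2 to compound 3 and a number 11 percentage points higher (beyond the scatter) from compound 1 to compound 4, 7 percentage points apart, within the scatter of two such steps In a physicochemical assay for lipophilicity, at pH 7.4 (a higher number here means a more lipophilic compound, a lower number a more polar compound), compound 1 gives 2.6 and compound 4 gives 3.3, a number 0.70 log units higher from compound 1 to compound 4 (beyond the scatter). Two pairs on two cores do not show that the step holds on any further core, and with the group at a different place in each pair, the effects of core and place cannot be separated.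

The compounds shown carry only methoxy or chloro at this place on the aromatic ring, so it remains open whether fluoro, trifluoromethyl, a nitrile or an amine would follow the same step. Going by these compounds, with a single pair of distribution coefficients, it also remains open whether the maximal response tracks that number across the series.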